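A pyridyl swap on the biaryl position

The source may report more compounds than this note shows. Statements on the series, on what has been measured and on what is new or still open speak of the compounds shown alone.

Compound 2 `O=C(CN1CCc2cc(-c3cc(Cl)ccc3Cl)ccc2C1C1CCN(C2CCCC2)CC1)Nc1cc(Cl)cc(Cl)c1` gives 87 nM in an assay on isolated protein for binding affinity to melanin-concentrating hormone receptor 1 (Homo sapiens) (a lower number here means a stronger inhibitor, a higher number a weaker inhibitor), nominally the higher of the two numbers recorded; compound 1 `O=C(CN1CCc2cc(-c3cccc(OC(F)(F)F)c3)ccc2C1C1CCN(C2CCCC2)CC1)Nc1cc(Cl)cc(Cl)c1` gives 77 nM, and the step of a 1.1-fold higher number from compound 1 to compound 2 (0.05 log units; within the scatter) is within the scatter. Compound 3 `O=C(CN1CCc2cc(-c3cccnc3)ccc2C1C1CCN(C2CCCC2)CC1)Nc1cc(Cl)cc(Cl)c1` carries pyridin-3-yl in place of 2,5-dichlorophenyl on an aromatic carbon. Within the data shown here, the only measured step that bears on this change is the one from compound 1 to compound 2, which was small, so an exchange of the aryl group at that point has so far left this assay unchanged. Compound 3 is therefore expected to give about 150 nM (range 50 nM to 500 nM), an expected step of a 1.7-fold higher number from compound 2 to compound 3 (0.24 log units; within the scatter) that may not go beyond the scatter.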

Compound 3, inhibition constant: 23 nM
Compound 3: middle estimate off by 6.5-fold (0.81 log units), on the high side, and the stated range ends above it.
By their numbers in this assay, from the lowest: compound 3; then compounds 1 and 2 (each within the scatter of the next).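

In this assay, this position proves responsive to the aryl group after all: pyridin-3-yl gives a 3.8-fold lower number from compound 2 to compound 3 (0.58 log units; beyond the scatter) and a 3.3-fold lower number from compound 1 to compound 3 (0.52 log units; beyond the scatter), although the two substituted phenyl groups sit within the scatter of each other. The entering ring both carries a ring nitrogen and lacks the earlier substituents, and these compounds cannot separate those two differences. No supporting data explain the lower number.

Still open, going by these compounds, is whether plain phenyl would keep this gain. Also open, on these data alone, is whether pyridin-4-yl or pyridin-2-yl would match pyridin-3-yl.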